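The compounds below may be only part of what the source reports. "The series", "measured", "known", "first", "only" and "open" are said of these compounds alone.

Compound 2 `COc1ccc(/C=C(/Sc2ccc(C)cc2)C(=O)c2ccc(Cl)cc2)cc1` bears a 4-methoxyphenyl on a double-bonded chain carbon bound to a double-bonded chain carbon. Going by the values given here, in a functional assay on DU-145 cells (Homo sapiens) for inhibition, read by trypan blue exclusion, with a stated time of 96 h (on this read-out lower numbers stand for stronger inhibition of growth and higher numbers for weaker inhibition of growth), compound 2 gives 1000 nM, the only plain number among the values shown. Compound 1 `Cc1ccc(S/C(=C/c2c(O)cc(O)cc2O)C(=O)c2ccc(Cl)cc2)cc1` reaches only a limit in this assay, > 100000 nM, namely (the limit of > 100000 nM in this assay, at which 1 of the 2 values shown sits). Among the compounds with values here, the one measured step at this position is an at least 100-fold lower number from compound 1 to compound 2 (2.00 log units; beyond the scatter), with 4-methoxyphenyl in place of 2,4,6-trihydroxyphenyl, which lowered the number far beyond the scatter.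

Compound 3 `Cc1ccc(S/C(=C/c2ccc(Cl)cc2Cl)C(=O)c2ccc(Cl)cc2)cc1` is the next compound, and it differs from compound 2 in one place: 2,4-dichlorophenyl in place of 4-methoxyphenyl on a double-bonded chain carbon bound to a double-bonded chain carbon. Within the data shown here, the step from compound 1 to compound 2 shows that this position tolerates a change of aryl group and that removing the 2,4,6-trihydroxyphenyl helped strongly, but no measured step covers a 2,4-dichlorophenyl at this site, so its own effect is unknown. In this assay a step from compound 2 to compound 3 of no more than the usual scatter is therefore expected, in either direction, as a 1.5-fold higher number from compound 2 to compound 3 (0.18 log units; within the scatter). Compound 3 is expected to give about 1500 nM, within a range from 300 nM to 8000 nM.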

Compound 3, concentration for 50% growth inhibition: 10000 nM
Compound 3: middle estimate off by 6.7-fold (0.82 log units), on the low side; the measured number lies above the stated range.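

In this assay, the aryl group on a double-bonded chain carbon bound to a double-bonded chain carbon proves to matter even among groups without hydroxyl substituents: 2,4-dichlorophenyl in place of 4-methoxyphenyl gives a 10-fold higher number from compound 2 to compound 3 (1.00 log units; beyond the scatter). Removing the 2,4,6-trihydroxyphenyl is therefore not enough in itself to reach the level of compound 2, although 2,4-dichlorophenyl in place of 2,4,6-trihydroxyphenyl still gives an at least 10-fold lower number from compound 1 to compound 3 (1.00 log units; beyond the scatter), so the three groups now fall into an order in which 4-methoxyphenyl stands first, 2,4-dichlorophenyl second and 2,4,6-trihydroxyphenyl last, with every step beyond the scatter. The figure for compound 1 is a limit and not a number, so the full size of its steps stays undefined: the limit of > 100000 nM in this assay, at which 1 of the 3 values shown sits.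

From the compounds shown here alone, it remains open whether an unsubstituted phenyl, a phenyl with a single chlorine, or a phenyl carrying an amine or a carboxylic acid at this position would fall nearer to compound 2 or to compound 3. Going by these compounds, it also remains open whether the same order of these three groups would hold with a different substituent elsewhere on the shared core.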